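From thiophen-2-yl to thiophen-3-yl on a shared core

A few compounds are considered here, and "the series" means these few. Any claim that something is new, unique, unknown or untested is made for them only; others in the source may bear on it.

Results in a functional assay on K562 cells (Homo sapiens), read by MTT assay, with a stated time of 72 h; a higher number here means a weaker inhibitor, a lower number a stronger inhibitor:
- compound 1 `C#Cc1cn([C@@H]2O[C@H](CO)[C@@H](O)[C@H]2O)c2ncnc(OC)c12` gives 380 nM
- compound 2 `CSc1ncnc2c1c(-c1ccoc1)cn2[C@@H]1O[C@H](CO)[C@@H](O)[C@H]1O` gives 3250 nM
- compound 3 `CSc1ncnc2c1c(-c1cccs1)cn2[C@@H]1O[C@H](CO)[C@@H](O)[C@H]1O` gives > 20000 nM (a limit, not a number)
- compound 4 `CSc1ncnc2c1c(-c1ccsc1)cn2[C@@H]1O[C@H](CO)[C@@H](O)[C@H]1O` has not yet been measured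

Compound 3 has no number on this scale and stands only at the limit of > 20000 nM in this assay, at which 1 of the 3 values shown sits. The next compound, compound 4, carries the same atoms joined differently, with thiophen-3-yl in place of thiophen-2-yl on an aromatic carbon. Among the compounds with values here, only one measured step bears on this change, and it lies beyond the scatter: an at least 6.1-fold higher number from compound 2 to compound 3 (0.78 log units; beyond the scatter). That step shows that the group at this carbon can matter in this assay, and the name of the group in compound 4 keeps the 3-yl ending of furan-3-yl in compound 2 . A lower number than the limit of compound 3 is therefore expected, though a result at the limit would not be surprising. The estimated size of the change is an at least 3.3-fold lower number from compound 3 to compound 4 (0.52 log units; beyond the scatter). The expected value for compound 4 is 6000 nM, with an estimated range from 1500 nM to 20000 nM.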

Compound 4, half-maximal inhibitory concentration: > 20000 nM
Compound 4: no number, only a limit (the forecaster's own chance of this, stated with the estimate: 25%); middle value at least 3.3-fold (0.52 log units) away from the limit.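

In this assay compound 4 gives > 20000 nM, which is a limit and not a number, so moving the point of attachment on the thiophene does not bring a value onto the scale. With thiophen-3-yl in place of furan-3-yl the result is an at least 6.1-fold higher number from compound 2 to compound 4 (0.78 log units; beyond the scatter), so the shared 3-yl ending alone does not keep the activity of compound 2, and among the three groups on this core only furan-3-yl gives a number. The step between the two thiophene compounds cannot be read, and they cannot be ranked, because both stand at the limit: the limit of > 20000 nM in this assay, at which 2 of the 4 values shown sit.

On these data alone, how far apart the two thiophene groups really lie stays open. So does whether furan-2-yl, phenyl or an aminomethyl group at this carbon on the same core would give a number.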